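The source may hold more compounds than are shown below. What is called first, only, known or untested is meant among the compounds shown, and "the series" means these compounds.

Compound 3 `CCOc1cc(NC(=O)CCCCCCC(=O)Nc2ccccc2N)cc2c1OCC([N+](=O)[O-])=C2` sits at the limit of a functional assay on HeLa cells (Homo sapiens) for antiproliferative activity, read by MTT assay, with a stated time of 48 h (on this read-out higher numbers stand for weaker inhibition of growth and lower numbers for stronger inhibition of growth), where it gives only > 20000 nM rather than a number. Compound 1 `CCOc1cc(NC(=O)CCCCCNC(=O)CCCc2ccccc2)cc2c1OCC([N+](=O)[O-])=C2` gives 6740 nM in this assay. Compound 2 `CCOc1cc(NC(=O)CCCCCCC(=O)Nc2cc(-c3ccc(C)s3)ccc2N)cc2c1OCC([N+](=O)[O-])=C2`, which carries a 5-methylthiophen-2-yl group, also returns only a limit, > 20000 nM. Compound 4 `CCOc1cc(NC(=O)CCCCCCC(=O)Nc2cc(-c3ccccc3)ccc2N)cc2c1OCC([N+](=O)[O-])=C2` differs from compound 3 by phenyl in place of hydrogen on an aromatic carbon. The closest measured step, a step that the two limits leave unreadable from compound 2 to compound 3, cannot be read because both values rest at the limit of > 20000 nM in this assay, at which 2 of the 3 values shown sit; the step of an at least 2.9-fold higher number from compound 1 to compound 3 (0.47 log units; beyond the scatter) concerns another part of the chain. With an aromatic group entering as in compound 2, compound 4 is expected to show a step that the limit leaves unreadable from compound 3 to compound 4 and most likely to stay at the limit. Compound 4 is estimated at 30000 nM, between 10000 nM and 100000 nM.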

Compound 4, concentration for 50% growth inhibition: 16200 nM
The estimate for compound 4 lay 1.9-fold (0.27 log units) above the measured number; the range from low to high includes it.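

Phenyl on this aromatic carbon, para to an amino group, gives a readable number in this assay, whereas hydrogen in compound 3 and 5-methylthiophen-2-yl in compound 2 each give only a limit: the limit of > 20000 nM in this assay, at which 2 of the 4 values shown sit. The change from hydrogen reads as an at least 1.2-fold lower number from compound 3 to compound 4 (0.09 log units; that floor lies within the scatter), and the exchange of rings reads as an at least 1.2-fold lower number from compound 2 to compound 4 (0.09 log units; that floor lies within the scatter). Both are floors, so neither step is shown to exceed the scatter.

As far as these compounds go, how far either step runs past its floor remains open, as does whether a pyridine ring or a 4-fluorophenyl group here would give a number.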